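The source may report more compounds than this note shows. Statements on the series, on what has been measured and on what is new or still open speak of the compounds shown alone.

Measured in a functional assay on aorta (Rattus norvegicus, strain Sprague-Dawley); on this read-out lower numbers stand for an effect already at smaller amounts and higher numbers for an effect only at larger amounts of compound:
compound 1 `Cc1nn(-c2ccccc2)c2nc(OCc3ccccc3F)c(-c3nc(N)cc(N)n3)cc12`: 2200 nM
compound 2 `Cc1nn(-c2ccccc2)c2nc(OCc3ccccc3F)c(-c3nc(N)c(N4CCCC4)c(N)n3)cc12`: 12700 nM

Compound 2 has the higher of these two numbers. Compound 3 `Cc1nn(-c2ccccc2)c2nc(OCc3ccccc3F)c(-c3nc(N)c(N(C)C)c(N)n3)cc12` differs from it in one place: dimethylamino in place of pyrrolidin-1-yl on an aromatic carbon. In short, dimethylamino stands in place of pyrrolidin-1-yl on an aromatic carbon. Among the compounds with values here, the only measured step that bears on this is a 5.8-fold higher number from compound 1 to compound 2 (0.76 log units; beyond the scatter), seen when pyrrolidin-1-yl replaced hydrogen on that same carbon. Compound 3 still carries a group there, so most of that step is expected to remain in this assay, with at most a small shift toward a lower number. The estimated step is a 1.4-fold lower number from compound 2 to compound 3 (0.15 log units; within the scatter). For compound 3 the expected value is 9000 nM, with an estimated range from 3500 nM to 22000 nM.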

Compound 3, half-maximal effective concentration: 1100 nM
For compound 3 the middle estimate is 8.2-fold (0.91 log units) above the measured one; measured number below the stated range.
By their numbers in this assay, from the lowest: compounds 3 and 1 (each within the scatter of the next); then compound 2.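

In this assay, a group on this aromatic carbon does not by itself raise the number: dimethylamino in place of pyrrolidin-1-yl gives a 12-fold lower number from compound 2 to compound 3 (1.06 log units; beyond the scatter) while dimethylamino in place of hydrogen gives a 2.0-fold lower number from compound 1 to compound 3 (0.30 log units; within the scatter) and so leaves compound 3 and compound 1 level. Which group sits there matters, not merely whether one does. Nothing available explains why these two groups differ. Diethylamino, an open group with longer chains, and morpholin-4-yl, a ring with a second hetero atom, remain open, so it is unclear whether the ring itself separates compound 2 from compound 3.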